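The source may report more compounds than this note shows. Statements on the series, on what has been measured and on what is new or still open speak of the compounds shown alone.

Measured so far:
compound 1 `Cc1cc(C)c(CN2CCc3c(F)cc(O[C@@H]4CCOC4)c(Cl)c3C2=O)c(=O)[nH]1` — 2.1
compound 2 `Cc1cc(C)c(CNC(=O)c2cccc(OC(C)C)c2Cl)c(=O)[nH]1` — 2

Two compounds carry a number in a physicochemical assay for lipophilicity, at pH 7.4; a higher number here means a more lipophilic compound, a lower number a more polar compound. Compound 1 gives 2.1 there, and compound 2 gives 2. Compound 1 has the higher of the two numbers, but the gap to compound 2 is within the scatter of repeated measurements, so the two cannot be told apart in this assay on these data alone.

The next compound, compound 3 `Cc1cc(C)c(CN2CCc3c(C)cc(O[C@@H]4CCOC4)c(Cl)c3C2=O)c(=O)[nH]1`, is drawn from compound 1 by a single change: methyl in place of fluoro on an aromatic carbon. Going by the values given here, no pair of measured compounds differs in one place, so there is no measured step to lean on here. An exchange of this kind is expected to shift this assay upward by a small amount, not far beyond the scatter. Compound 3 is therefore estimated at 2.5, with a range from 2.1 to 2.9. The expected step of a number 0.40 log units higher from compound 1 to compound 3 (beyond the scatter) is a modest rise.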

Compound 3, distribution coefficient: 2.1
Compound 3: middle estimate off by 0.40 log units, on the high side; low and high end bracket the measured number.
By their numbers in this assay, from the lowest: compounds 2, 1 and 3 (each within the scatter of the next).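

This is the first pair among the compounds shown that differs in one place, so it gives the first direct reading of a single exchange in this assay. On the aromatic carbon para to a chloro group and ortho to a fused ring, methyl in place of fluoro gives no change at the digits printed from compound 1 to compound 3 (within the scatter), so in this core the two groups cannot be told apart in this assay. Nothing on hand accounts for this result.

The reading rests on one pair in one core, and it cannot say whether the same exchange would read alike at another aromatic carbon or with the (oxolan-3-yl)oxy group replaced. As far as these compounds go, how a larger group on this carbon, such as ethyl, an amine or a carboxylic acid, would read in this assay also remains open.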